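From methyl to benzyl on the shared core

A few compounds are considered here, and "the series" means these few. Any claim that something is new, unique, unknown or untested is made for them only; others in the source may bear on it.

Compound 2 `COC(=O)/C=C\NC(=O)[C@@H](O)C(C)(C)CO` gives -20% in an ADME assay on WI-38 cells (Homo sapiens) for inhibition, read by CellTiter-Glo, with a stated time of 48 h, tested at 100 uM (a higher number here means more inhibition at the concentration tested (going by the name of the read-out), a lower number less inhibition), the lower of the two numbers measured, while compound 1 `CCOC(=O)/C=C\NC(=O)[C@@H](O)C(C)(C)CO` gives -6%. Compound 3 `CC(C)(CO)[C@H](O)C(=O)N/C=C\C(=O)OCc1ccccc1` differs from compound 2 by phenyl in place of hydrogen on a saturated chain carbon bound to an oxygen next to a carbonyl group. For the measured compounds named here, the only step that bears on this change is a number 14 percentage points lower from compound 1 to compound 2 (beyond the scatter), which runs in the reverse direction at the same place. Putting a group back there is therefore expected to raise the number by a modest step, a number 18 percentage points higher from compound 2 to compound 3 (beyond the scatter), though the entering phenyl is larger than the methyl that was removed. Compound 3 is estimated at -2%, within a range of -25% to 22%.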

Compound 3, a percentage reported as inhibition, at one concentration (the size of the read-out at that concentration, not a potency): -2%
Compound 3: the middle estimate sits on the measured number at the digits printed, within the range that was stated.
By their numbers in this assay, from the lowest: compound 2; then compounds 1 and 3 (each within the scatter of the next).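

Phenyl in place of hydrogen on a saturated chain carbon bound to an oxygen next to a carbonyl group gives (a number 18 percentage points higher from compound 2 to compound 3 (beyond the scatter)) in this assay, so the number at this place is not raised by methyl alone. Phenyl in place of methyl gives (a number 4 percentage points higher from compound 1 to compound 3 (within the scatter)), so the larger group cannot be told apart from methyl here. The compounds shown leave open whether an amine, a carboxylic acid or a longer chain at this place would give a number like those of the methyl and phenyl cases. Nothing given here offers a reason for these steps.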